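The source may hold more compounds than are shown below. What is called first, only, known or untested is meant among the compounds shown, and "the series" means these compounds.

Measured compounds:
- compound 1 `CN(C)CCn1cnnc1-c1cc(Oc2ccc(NC(=O)N/N=C/c3ccc(Cl)cc3Cl)cc2F)ccn1`: 4760 nM
- compound 2 `CN(C)CCn1cnnc1-c1cc(Oc2ccc(NC(=O)N/N=C/c3c(Cl)cccc3Cl)cc2F)ccn1`: 3320 nM
- compound 3 `CN(C)CCn1cnnc1-c1cc(Oc2ccc(NC(=O)N/N=C/c3cc(C(C)(C)C)cc(C(C)(C)C)c3O)cc2F)ccn1`: 2350 nM

In an ADME assay on WI-38 cells (Homo sapiens) for cytotoxicity, read by MTT assay, with a stated time of 72 h (on this read-out lower numbers stand for stronger inhibition and higher numbers for weaker inhibition), compound 2 stands second highest of the three numbers, with compound 3 nearest and compound 1 furthest, both gaps within the scatter. Compound 4 `COc1ccc(/C=N/NC(=O)Nc2ccc(Oc3ccnc(-c4nncn4CCN(C)C)c3)c(F)c2)c(OC)c1` carries 2,4-dimethoxyphenyl in place of 2,6-dichlorophenyl on a carbon with a double bond to nitrogen. For the measured compounds named here, the only measured step at that carbon is a 1.4-fold lower number from compound 1 to compound 2 (0.16 log units; within the scatter), an exchange of one substituted phenyl for another that stayed within the scatter. Nothing measured separates a dimethoxy-bearing phenyl from a dichloro-bearing one, so no step beyond the scatter is expected in this assay. Compound 4 is therefore estimated at 3300 nM, within 1500 nM to 7500 nM, which corresponds to an expected step of a 1.0-fold lower number from compound 2 to compound 4 (0.00 log units; within the scatter).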

Compound 4, half-maximal inhibitory concentration: 6630 nM
The estimate for compound 4 lay 2.0-fold (0.30 log units) below the measured number; the range from low to high includes it.
By their numbers in this assay, from the lowest: compounds 3, 2, 1 and 4 (each within the scatter of the next, the first and the last beyond it).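

In this assay the 2,4-dimethoxyphenyl group gives a 2.0-fold higher number from compound 2 to compound 4 (0.30 log units; within the scatter) and a 1.4-fold higher number from compound 1 to compound 4 (0.14 log units; within the scatter) at the carbon with a double bond to nitrogen. This position has thus taken a group with two hydrogen-bond acceptors in place of dichlorophenyl groups with none, without a step beyond the scatter. Nothing shown here accounts for these steps. As far as these compounds go, whether an amine or a carboxylic acid on this phenyl would give a step beyond the scatter stays open, as does the effect of an unsubstituted phenyl at this position.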